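Isopropylcarbonyl to propanoyl, checked across two cores

The source may report more compounds than this note shows. Statements on the series, on what has been measured and on what is new or still open speak of the compounds shown alone.

Of the compounds shown here, three of the set carry a value so far. In an assay on HEK293 cells for positive allosteric modulation of metabotropic glutamate receptor 2 (Rattus norvegicus), read by thallium flux, with a stated time of 2.5 min (on this read-out lower numbers stand for an effect already at smaller amounts and higher numbers for an effect only at larger amounts of compound), compound 1 `Cc1c(OCCCCOc2ccc(C(=O)C(C)C)c(O)c2C)cccc1C(=O)O` gives 149 nM. Compound 3 `COc1ccc(C(=O)O)cc1OCCCCOc1ccc(C(=O)C(C)C)c(O)c1C` gives 116 nM in this assay, and compound 2 `CCC(=O)c1ccc(OCCCCOc2cc(C(=O)O)ccc2OC)c(C)c1O` gives 162 nM. Compound 2 differs from compound 3 in one place, (hydrogen in place of methyl on a saturated chain carbon bound to a carbonyl carbon and a saturated chain carbon), and that change made a 1.4-fold higher number from compound 3 to compound 2 (0.15 log units; within the scatter). The difference between the core of compound 1 and the core of compound 3 is not broken down here; their two values stand within the scatter of each other.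

Compound 4 `CCC(=O)c1ccc(OCCCCOc2cccc(C(=O)O)c2C)c(C)c1O` has not been measured. Among the compounds with values here, it differs from compound 1 by hydrogen in place of methyl on a saturated chain carbon bound to a carbonyl carbon and a saturated chain carbon, the same change as the one from compound 3 to compound 2, and the place is described in the same words for both. The expectation in this assay rests on that single measured instance, which stayed within the scatter. Within the data shown here, the expected step is a 1.3-fold higher number from compound 1 to compound 4 (0.13 log units; within the scatter), taken from a 1.4-fold higher number from compound 3 to compound 2 (0.15 log units; within the scatter) as the only precedent. Among the measured compounds shown here, compound 4 is therefore estimated at 200 nM, with a range from 100 nM to 400 nM that allows for the scatter and for the single precedent.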

Compound 4, half-maximal effective concentration: 62 nM
Compound 4: the middle estimate sits 3.2-fold (0.51 log units) above what was measured; the whole stated range lies above it.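

In this assay, the change from isopropylcarbonyl to propanoyl does not act as a fixed step that can be carried from one core to the other, since its two instances differ: the same change on two cores in this assay, a 1.4-fold higher number (0.15 log units; within the scatter) from compound 3 to compound 2 and a 2.4-fold lower number (0.38 log units; beyond the scatter) from compound 1 to compound 4, 3.4-fold (0.53 log units) apart, beyond the scatter of two such steps

On the core of compound 1, the new step is a 2.4-fold lower number from compound 1 to compound 4 (0.38 log units; beyond the scatter), whereas the pair on the core of compound 3 stays within the scatter. This shows that a result on one core did not predict the result on the other in this pair of cores; it does not show which feature of the cores goes with the difference, and one instance per core gives no rule for any further core.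

The compounds shown leave open how other groups in the place of isopropylcarbonyl, such as acetyl or cyclopropylcarbonyl, would behave on these two cores. They also leave open whether the lower number seen with propanoyl on the core of compound 1 would recur on a core carrying an amine.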